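The compounds below may be only part of what the source reports. "The series", "measured", "known", "first", "only" and "open" are said of these compounds alone.

Within the data shown here, compound 2 `C=C1[C@@H](O)C[C@H]2C(C)(C)CCC[C@]2(C)[C@H]1/C=C/C1=CCOC1=O` gives 14.8 ug/mL in a functional assay on HeLa cells (Homo sapiens) for cytotoxicity, read by sulforhodamine B assay, with a stated time of 48 h (a lower number here means a stronger inhibitor, a higher number a weaker inhibitor), and stands highest of the two numbers so far; its only neighbour is compound 1 `C=C1[C@@H](O)C[C@H]2C(C)(C)CCC[C@]2(C)[C@H]1/C=C/C1=CC(=O)OC1O`, which in this assay gives 9.21 ug/mL. Among the measured compounds shown here, the one measured step, a 1.6-fold higher number from compound 1 to compound 2 (0.21 log units; within the scatter), concerns the group on the double-bonded chain carbon and says nothing about the ring. Compound 3 `C=C1[C@@H](O)[C@@H](O)[C@H]2C(C)(C)CCC[C@]2(C)[C@H]1/C=C/C1=CCOC1=O` differs from compound 2 by hydroxy in place of hydrogen on a saturated ring carbon. For the measured compounds named here, no measured step touches this position, so no shift beyond the scatter is expected, a 1.0-fold higher number from compound 2 to compound 3 (0.01 log units; within the scatter). Compound 3 is accordingly expected to give about 15 ug/mL in this assay, within 6 ug/mL to 35 ug/mL.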

Compound 3, half-maximal inhibitory concentration: > 25 ug/mL
Compound 3 ended at the assay's limit; the forecaster's own chance of this, stated with the estimate: 5%; at least 1.6-fold (0.22 log units) between middle value and limit.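

In this assay compound 3 gives > 25 ug/mL, which is a limit of the assay and not a number. Hydroxy in place of hydrogen on this saturated ring carbon gives an at least 1.6-fold higher number from compound 2 to compound 3 (0.22 log units; that floor lies within the scatter), so this first change at the position brings no gain, while its true size stays unknown. The step is therefore only a floor: the limit of > 25 ug/mL in this assay, at which 1 of the 3 values shown sits.

Going by these compounds, whether the change carries a real loss remains open, as does whether a methoxy group or an amine on this ring carbon would read like hydroxy. Also open, on these data alone, is whether the same change would read alike with the five-membered ring group of compound 1.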